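The source may report more compounds than this note shows. Statements on the series, on what has been measured and on what is new or still open speak of the compounds shown alone.

Three compounds built on one shared core have been run through an ADME assay on microsomes from liver (Homo sapiens) for metabolic stability, tested at 2.5 uM; a higher number here means faster removal of the compound, a lower number slower removal. Compound 1 `COc1ccc(-c2c(S(=O)(=O)c3cccc(F)c3)cnc3cc(F)ccc23)cc1` gives 1.89 mL/min. Compound 2 `COc1ccc(-c2c(S(=O)(=O)c3ccc(OC)cc3)cnc3cc(F)ccc23)cc1` gives 1.18 mL/min, and the step from compound 1 to compound 2 is a 1.6-fold lower number from compound 1 to compound 2 (0.20 log units; within the scatter). Compound 3 `O=S(=O)(c1cccc(F)c1)c1cnc2cc(F)ccc2c1-c1ccc(F)cc1` gives 0.11 mL/min, which is the lowest of the three numbers: the gap to compound 2 lies beyond the scatter, and the change from compound 1 to compound 3 is a 17-fold lower number from compound 1 to compound 3 (1.24 log units; beyond the scatter), the largest movement seen here.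

Compound 4 `COc1ccc(S(=O)(=O)c2cnc3cc(F)ccc3c2-c2ccc(F)cc2)cc1` is the next compound. Relative to compound 3 it differs in one place: 4-methoxyphenyl in place of 3-fluorophenyl on a sulfonyl sulfur. The same exchange has been seen once already, between compound 1 and compound 2, where it produced a 1.6-fold lower number from compound 1 to compound 2 (0.20 log units; within the scatter), a shift too small to count as a real difference. On that basis compound 4 is expected to stay close to compound 3 in this assay, with an expected step of a 1.4-fold lower number from compound 3 to compound 4 (0.14 log units; within the scatter), that is, no change beyond the scatter in either direction. The estimated value for compound 4 is therefore 0.08 mL/min, with a range from 0.03 mL/min to 0.25 mL/min.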

Compound 4, intrinsic clearance in a liver preparation (reported as CLH), per the amount of preparation that the assay uses: 1.71 mL/min
The estimate for compound 4 lay 21-fold (1.33 log units) below the measured number, and the stated range ends below it.
By their numbers in this assay, from the lowest: compound 3; then compounds 2, 4 and 1 (each within the scatter of the next).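

In this assay, putting 4-methoxyphenyl in place of 3-fluorophenyl on a sulfonyl sulfur has no fixed effect, and here it gives a 16-fold higher number from compound 3 to compound 4 (1.19 log units; beyond the scatter), so its outcome depends on what the rest of the molecule carries: the same change on two cores in this assay, a 1.6-fold lower number (0.20 log units; within the scatter) from compound 1 to compound 2 and a 16-fold higher number (1.19 log units; beyond the scatter) from compound 3 to compound 4, 25-fold (1.40 log units) apart, beyond the scatter of two such steps. The other change, fluoro in place of methoxy on an aromatic carbon, now also proves to depend on its surroundings, giving a 1.4-fold higher number from compound 2 to compound 4 (0.16 log units; within the scatter) when a 4-methoxyphenyl sits on the sulfonyl sulfur: the same change on two cores in this assay, a 17-fold lower number (1.24 log units; beyond the scatter) from compound 1 to compound 3 and a 1.4-fold higher number (0.16 log units; within the scatter) from compound 2 to compound 4, 25-fold (1.40 log units) apart, beyond the scatter of two such steps. Among these four compounds, only compound 3 carries no methoxy group and only compound 3 has a low number, while compounds 1, 2 and 4, with a methoxy group in one place or both, stand within the scatter of their neighbours in the order.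

Still open, on these data alone, is which half of the sulfonyl swap counts, the loss of the 3-fluorophenyl or the arrival of the 4-methoxyphenyl, a question that a plain phenyl on the sulfonyl sulfur would help to separate. Also open, as far as these compounds go, is whether a different group at these places, such as a hydroxyl, a chlorine or an amine, would behave as methoxy does.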